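The source may report more compounds than this note shows. Statements on the series, on what has been measured and on what is new or still open speak of the compounds shown alone.

Compound 1 `COc1ccc(CN(c2cc(OC)c(OC)c(OC)c2)S(=O)(=O)c2ccc(C)cc2)cc1` gives 10100 nM in a functional assay on MCF7 cells (Homo sapiens) for inhibition, read by MTT assay, with a stated time of 48 h; a lower number here means a stronger inhibitor, a higher number a weaker inhibitor. Compound 2 `COc1ccc(CN(c2cc(OC)c(OC)c(OC)c2)S(=O)(=O)c2ccc(C(C)(C)C)cc2)cc1` differs from it by tert-butyl in place of methyl on an aromatic carbon and gives 32700 nM in this assay, so that the step of a 3.2-fold higher number from compound 1 to compound 2 (0.51 log units; beyond the scatter). Compound 3 `COc1cc(N(Cc2nc3ccccc3[nH]2)C(=O)c2ccc(C)cc2)cc(OC)c1OC` is built on another core, and the difference between the two cores is not broken down here; in this assay compound 3 gives 49300 nM, a number close to that of compound 2. Compound 4 `COc1cc(N(Cc2nc3ccccc3[nH]2)C(=O)c2ccc(C(C)(C)C)cc2)cc(OC)c1OC` stands to compound 3 as compound 2 stands to compound 1, through (tert-butyl in place of methyl on an aromatic carbon), the same change at the same place. Among the measured compounds shown here, the step to compound 4 is expected to be a 2.4-fold higher number from compound 3 to compound 4 (0.39 log units; beyond the scatter), resting on a 3.2-fold higher number from compound 1 to compound 2 (0.51 log units; beyond the scatter) as the only measured instance of this change. Compound 4 is therefore expected to give 120000 nM, most likely between 45000 nM and 300000 nM.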

Compound 4, half-maximal inhibitory concentration: 48800 nM
For compound 4 the middle estimate is 2.5-fold (0.39 log units) above the measured one, within the range that was stated.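

In this assay, tert-butyl in place of methyl on the core of compound 3 gives a 1.0-fold lower number from compound 3 to compound 4 (0.00 log units; within the scatter), so this pair cannot be told apart. The change therefore did not carry over from one core to the other with the same size: the same change on two cores in this assay, a 3.2-fold higher number (0.51 log units; beyond the scatter) from compound 1 to compound 2 and a 1.0-fold lower number (0.00 log units; within the scatter) from compound 3 to compound 4, 3.3-fold (0.51 log units) apart, beyond the scatter of two such steps. Among the compounds shown here, this rests on one pair per core, so it shows only that the step cannot be assumed to transfer between these two cores; it does not show which difference between them accounts for the gap, or how the change would read on a further core.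

The compounds shown leave open how an amine or a carboxylic acid in place of methyl would read on either core. They also leave open whether a group of intermediate size, such as an ethyl, would follow the step seen on one core or the other.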